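Propyl, isopropyl, butyl: a chain at the limit

The source may hold more compounds than are shown below. What is called first, only, known or untested is meant among the compounds shown, and "the series" means these compounds.

The shared core carries an ether on a saturated ring carbon, and the two measured compounds differ only in that chain. Compound 1 `CCCO[C@@]1(C(=O)O)C=C[C@@H](NC(C)=O)[C@H]([C@H](O)[C@H](O)CO)O1` bears a propyl group there. In an assay on HEK293 cells for inhibition of sialidase-3 (Homo sapiens), read by fluorescence, with a stated time of 1 h (on this read-out higher numbers stand for weaker inhibition and lower numbers for stronger inhibition), compound 1 gives > 1000000 nM, which is a limit of the assay and not a number. Compound 2 `CC(=O)N[C@@H]1C=C[C@@](OC(C)C)(C(=O)O)O[C@H]1[C@H](O)[C@H](O)CO` bears an isopropyl group in the same place. In this assay compound 2 gives > 1000000 nM, again a limit rather than a number. The step that the two limits leave unreadable from compound 1 to compound 2 therefore cannot be sized, since both values sit at the limit of > 1000000 nM in this assay, at which 2 of the 2 values shown sit. Among the measured compounds shown here, compound 2 thus stands at the limit, alongside the one other value shown.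

Compound 3 `CCCCO[C@@]1(C(=O)O)C=C[C@@H](NC(C)=O)[C@H]([C@H](O)[C@H](O)CO)O1` differs from compound 2 in one place: butyl in place of isopropyl on an oxygen on a saturated carbon. For the measured compounds named here, the single measured step, propyl to isopropyl, bears on this change, and its size is unreadable; neither the longer nor the branched chain has moved the read-out off the limit. No step beyond the scatter is therefore expected in this assay in either direction. For compound 3 the estimate is 2000000 nM, with a range from 500000 nM to 10000000 nM, and the step expected from this estimate is a step that the limit leaves unreadable from compound 2 to compound 3.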

Compound 3, half-maximal inhibitory concentration: > 1000000 nM
Compound 3 ended at the assay's limit (the forecaster's own chance of this, stated with the estimate: 85%); the middle value does not contradict the limit.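

In this assay compound 3 gives > 1000000 nM, which is a limit of the assay and not a number. Among the compounds shown here, no step linking compound 3 with compound 1 or compound 2 can therefore be read: the limit of > 1000000 nM in this assay, at which 3 of the 3 values shown sit. The compounds shown leave open how far propyl, isopropyl and butyl differ, and whether any chain here would give a value off the limit.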